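Fluoro in place of methyl on the ether-bearing ring

This account rests on a few compounds, and the source may have more. Where it says the series, first, only, none or still open, it means among the compounds named here.

Compound 1 `CNc1cc(Oc2ccc(NC(=O)Nc3cccc(C(F)(F)F)c3)c(F)c2F)ncn1` and compound 2 `CNc1cc(Oc2ccc(NC(=O)Nc3cccc(C(F)(F)F)c3)cc2C)ncn1` share one core and differ only in the substituents on the aromatic ring that carries the ether. In an assay on isolated protein for inhibition of serine/threonine-protein kinase TNNI3K (Homo sapiens) (on this read-out lower numbers stand for stronger inhibition and higher numbers for weaker inhibition), compound 1 gives 20 nM. For compound 2 the result in this assay is <= 10 nM, which is a limit of the assay and not a number. Compound 2 therefore stands at the limit of <= 10 nM in this assay, at which 1 of the 2 values shown sits, and its distance from compound 1 cannot be fixed beyond that. Compound 3 `CNc1cc(Oc2ccc(NC(=O)Nc3cccc(C(F)(F)F)c3)cc2F)ncn1` is not yet measured in this assay. It differs from compound 2 by fluoro in place of methyl on an aromatic carbon, ortho to a (6-(methylamino)pyrimidin-4-yl)oxy group and meta to a large group. Among the compounds with values here, no measured pair shows this exchange, so no step size is on hand. With both measured values at the strong end of the assay, the step from compound 2 to compound 3 is expected to be an at least 1.4-fold higher number from compound 2 to compound 3 (0.14 log units; that floor lies within the scatter), not beyond the usual scatter in either direction. Compound 3 is estimated at 14 nM, with a range from 5 nM to 40 nM.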

Compound 3, half-maximal inhibitory concentration: 25 nM
Compound 3: middle estimate off by 1.8-fold (0.25 log units), on the low side; the range from low to high includes it.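

In this assay, fluoro in place of methyl on the aromatic carbon ortho to the (6-(methylamino)pyrimidin-4-yl)oxy group gives an at least 2.5-fold higher number from compound 2 to compound 3 (0.39 log units; beyond the scatter), so this position does respond to the exchange, and the methyl of compound 2 reads stronger than the fluoro of compound 3. The true size of that step remains a floor, since compound 2 is held only by a limit of the assay: the limit of <= 10 nM in this assay, at which 1 of the 3 values shown sits. By contrast, hydrogen in place of fluoro on an aromatic carbon gives a 1.3-fold higher number from compound 1 to compound 3 (0.10 log units; within the scatter), so this second exchange does not separate the two groups on this read-out, and the result at the methyl-bearing position is not matched by a comparable shift at the other.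

Going by these compounds, how far the true value of compound 2 lies from that of compound 3 stays open. On these data alone, whether the preference extends past methyl also stays open, and a chloro, an ethyl or a methoxy group on the same carbon, or a plain hydrogen there, would be needed to settle it.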